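A few compounds are considered here, and "the series" means these few. Any claim that something is new, unique, unknown or untested is made for them only; others in the source may bear on it.

Measured so far:

Compound 1 `CN1CCN(CCNCc2cn(-c3ccc(F)cc3F)nc2-c2ccc(Cl)cc2)CC1`: 19000 nM
Compound 2 `CSc1ccc(-n2cc(CNCCN3CCN(C)CC3)c(-c3ccccc3C)n2)cc1`: 17000 nM
Compound 3 `Cc1ccccc1-c1nn(-c2ccc(F)cc2F)cc1CNCCCN1CCN(C)CC1`: > 20000 nM

In an ADME assay on Huh-7 cells (Homo sapiens) for cytotoxicity (a lower number here means that less compound is tolerated, a higher number that more compound is tolerated), compound 1 gives 19000 nM, the higher of the two plain numbers, though compound 2 with 17000 nM sits within the scatter of it, so the two cannot be ranked. Compound 3 reaches only a limit of the assay, > 20000 nM, and no number is known for it (the limit of > 20000 nM in this assay, at which 1 of the 3 values shown sits).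

Compound 4 `CN1CCN(CCNCc2cn(-c3ccc(F)cc3F)nc2-c2ccc(C(F)(F)F)cc2)CC1` is not yet measured. It differs from compound 1 in one place: trifluoromethyl in place of chloro on an aromatic carbon. Within the data shown here, no measured pair here changes the same group, so no step of known size points the way; all three measured values sit near the upper edge of what this assay reports. Compound 4 is therefore expected to stay close to compound 1, with a step of a 1.3-fold lower number from compound 1 to compound 4 (0.10 log units; within the scatter) no larger than the scatter. The estimate for compound 4 is 15000 nM, between 6000 nM and 40000 nM.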

Compound 4, half-maximal cytotoxic concentration: 20000 nM
Beside the measured number, compound 4's estimate is 1.3-fold (0.12 log units) below it; measured number inside the range.
By their numbers in this assay, from the lowest: compounds 2, 1 and 4 (each within the scatter of the next).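

In this assay, among these compounds, the swap from 4-chlorophenyl to 4-(trifluoromethyl)phenyl gives a 1.1-fold higher number from compound 1 to compound 4 (0.02 log units; within the scatter), the first step of known size at this position. The larger group, with more heavy atoms, therefore leaves the read-out unchanged within the scatter. This step also lies near the upper edge of what the assay reports: the limit of > 20000 nM in this assay, at which 1 of the 4 values shown sits.

As far as these compounds go, whether an amine, a hydroxyl group or a carboxylic acid on this aromatic carbon would move the number beyond the scatter stays open.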